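The source may hold more compounds than are shown below. What is called first, only, known or untested is meant among the compounds shown, and "the series" means these compounds.

All three measured compounds were tested in an assay on isolated protein for inhibition of 2-Hydroxyacid oxidase 2 (Homo sapiens), tested at 1 uM; a higher number here means a stronger effect of the compound at the concentration tested, a lower number a weaker effect:

compound 1, `Cc1n[nH]c(C(=O)O)c1Cc1cccc(-c2ccc(OC(F)(F)F)cc2)c1`, gives 6%
compound 2, `Cc1n[nH]c(C(=O)O)c1Cc1cccc(-c2ccc(C(F)(F)F)cc2)c1`, gives 8%
compound 3, `Cc1n[nH]c(C(=O)O)c1Cc1ccc(-c2ccc(C(F)(F)F)cc2)cc1`, gives 5%

The three numbers lie close together, and none of the gaps between them is larger than the usual scatter of repeated measurements, so no order among them can be read from these data.

Compound 2 and compound 1 share a core and differ in one place: trifluoromethoxy in place of trifluoromethyl on an aromatic carbon. This change made a step of a number 2 percentage points lower from compound 2 to compound 1 (within the scatter). Compound 3 is built from the same atoms as compound 2, joined differently; the difference between the two cores is not broken down here.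

Compound 4, `Cc1n[nH]c(C(=O)O)c1Cc1ccc(-c2ccc(OC(F)(F)F)cc2)cc1`, has not yet been measured in this assay. It stands to compound 3 as compound 1 stands to compound 2: trifluoromethoxy in place of trifluoromethyl on an aromatic carbon. The description of the place is the same word for word in both cases, so this is the same change made on a second core. It occurs twice among the compounds shown, once measured and once not.

The expectation for compound 4 rests on two things: the earlier instance of this change gave a number 2 percentage points lower from compound 2 to compound 1 (within the scatter), a step within the scatter, and compound 3 itself gives 5%. The step from compound 3 to compound 4 is therefore estimated as a number 1 percentage points lower from compound 3 to compound 4 (within the scatter). Compound 4 is expected to give 4%, with a plausible range from -4% to 13%.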

Compound 4, a percentage reported as inhibition, at one concentration (the size of the read-out at that concentration, not a potency): 11%
Beside the measured number, compound 4's estimate is 7 percentage points below it, and the stated range covers the measured number.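

Carried to the second core in this assay, the exchange of trifluoromethyl for trifluoromethoxy gave a number 6 percentage points higher from compound 3 to compound 4 (within the scatter). Set beside the earlier instance, the two steps point in opposite directions on paper, yet they cannot be told apart: the same change on two cores in this assay, a number 2 percentage points lower (within the scatter) from compound 2 to compound 1 and a number 6 percentage points higher (within the scatter) from compound 3 to compound 4, 8 percentage points apart, within the scatter of two such steps. For the compounds shown here, what this shows is that, on these two cores, the change produced no step that stands clear of the scatter, and nothing here indicates that its outcome depends on the core; it does not show that the change is without effect or that it acts alike on both cores, for each core supplies only one pair of compounds, each compound was read at a single concentration, and all four numbers lie close together.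

The compounds shown all carry trifluoromethyl or trifluoromethoxy on the outer aromatic ring, along with the same carboxylic acid and methyl group on the shared core, so they leave open whether any other group in that place, such as a nitrile or an amine, would move the read-out beyond the scatter. They also leave open what a primary amide in place of the carboxylic acid, or a longer chain in place of the methyl group, would do.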